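Benzimidazole-thiazole piperazines: hydroxymethyl to (dimethylamino)methyl

The source may report more compounds than this note shows. Statements on the series, on what has been measured and on what is new or still open speak of the compounds shown alone.

Two compounds of the series have numbers in a functional assay on CHO-K1 cells for antagonist activity at C-X-C chemokine receptor type 3 (Homo sapiens), read by FLIPR, with a stated time of 10 min; a lower number here means a stronger inhibitor, a higher number a weaker inhibitor. Compound 1 `C[C@@H]1CN(c2sc(C3CC3)nc2-c2nc3ccccc3[nH]2)CCN1C(=O)Cn1cnc2cccnc21` gives 9.7 nM. Going by the values given here, compound 2 `C[C@@H]1CN(c2sc(CO)nc2-c2nc3ccccc3[nH]2)CCN1C(=O)Cn1cnc2cccnc21` gives 171 nM, the higher of the two numbers; the single measured step, an 18-fold higher number from compound 1 to compound 2 (1.25 log units; beyond the scatter), is the only guide to how much this position moves the read-out. Compound 3 `C[C@@H]1CN(c2sc(CN(C)C)nc2-c2nc3ccccc3[nH]2)CCN1C(=O)Cn1cnc2cccnc21` is not yet measured. The change from compound 2 is dimethylamino in place of hydroxy on a saturated chain carbon bound to an aromatic carbon. Among the compounds with values here, no measured pair shows this exchange, so its direction is not known from the data; the step from compound 1 to compound 2 only shows that a change at this position can be large. The number for compound 3 is estimated to fall between those of the two measured compounds, giving an expected step of a 2.9-fold lower number from compound 2 to compound 3 (0.45 log units; beyond the scatter) in this assay. Compound 3 is therefore expected at 60 nM, within a range of 15 nM to 250 nM.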

Compound 3, half-maximal inhibitory concentration: 50 nM
For compound 3 the middle estimate is 1.2-fold (0.08 log units) above the measured one; the range from low to high includes it.
By their numbers in this assay, from the lowest: compound 1; then compound 3; then compound 2.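

In this assay the exchange now has a measured direction: a 3.4-fold lower number from compound 2 to compound 3 (0.53 log units; beyond the scatter) for dimethylamino in place of hydroxy on a saturated chain carbon bound to an aromatic carbon. Cyclopropyl still gives the lowest number of the three, with a 5.2-fold higher number from compound 1 to compound 3 (0.71 log units; beyond the scatter) left over, so (dimethylamino)methyl recovers only part of the loss seen with hydroxymethyl. Nothing shown gives a reason for either step.

The compounds shown leave open whether the lower number goes with the amine nitrogen or simply with the larger group; an isobutyl group, with carbon in place of that nitrogen, would separate the two. On these data alone, it also remains open whether a ring amine such as morpholine on the same chain carbon would come closer to cyclopropyl.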